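A few compounds are considered here, and "the series" means these few. Any claim that something is new, unique, unknown or untested is made for them only; others in the source may bear on it.

Compound 1 `Cc1nn(-c2ccccn2)c2cc(-c3ccc(CCC(=O)O)cc3)ccc12` gives 95% in a functional assay on cells for agonist activity at Free fatty acid receptor 1 (Mus musculus), read by FLIPR and calcium flux, with a stated time of 5 min; a lower number here means a smaller maximal response, a higher number a larger maximal response. Compound 2 `Cc1nn(-c2ccccn2)c2cc(-c3ccc(CC(C)(C)C(=O)O)cc3)ccc12` gives 18%. Compound 3 `Cc1nn(-c2ccccn2)c2cc(-c3ccc(CCC(=O)O)cc3C#N)ccc12` gives 47%.

Among the three measured compounds, compound 1 shows the largest maximal response; compound 3 lies a number 48 percentage points lower from compound 1 to compound 3 (beyond the scatter) and compound 2 lies a number 77 percentage points lower from compound 1 to compound 2 (beyond the scatter), both beyond the scatter. Compound 4 `CCc1nn(-c2ccccn2)c2cc(-c3ccc(CCC(=O)O)cc3)ccc12` keeps the shared core of compound 1 and differs from it only by methyl in place of hydrogen on a saturated chain carbon bound to an aromatic carbon.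

Neither measured step touches this place. The change from compound 1 to compound 2 alters the acid chain, and the change from compound 1 to compound 3 adds a cyano group to the aromatic ring; both cut the response sharply, so the core of compound 1 tolerates those changes poorly. Among the measured compounds shown here, the step to compound 4 is a single added carbon on the methyl of the core, and no measured pair speaks to it. A small step, within or near the scatter, is therefore expected for compound 4, with the value for compound 4 estimated at 85% (range 55% to 105%), which means an expected step of a number 10 percentage points lower from compound 1 to compound 4 (within the scatter).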

Compound 4, largest response reached (reported as efficacy), in percent of the reference or control that the assay uses: 93%
Compound 4: the middle estimate sits 8 percentage points below what was measured; measured number inside the range.
By their numbers in this assay, from the lowest: compound 2; then compound 3; then compounds 4 and 1 (each within the scatter of the next).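

In this assay, the step of a number 2 percentage points lower from compound 1 to compound 4 (within the scatter) shows that this place, a saturated chain carbon bound to an aromatic carbon, accepts methyl in place of hydrogen. The maximal response stays within the scatter of compound 1, which sets this change apart from the two changes shown earlier on the acid chain and the aromatic ring, both of which lay beyond the scatter. Nothing available explains why methyl to ethyl is accepted here.

Still open, from the compounds shown here alone, is how far this place can be extended, which a propyl chain, an isopropyl group or a cyclopropyl ring would test. It is also unclear whether ethyl on the shared core would change the outcome of the cyano group on the aromatic carbon.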